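A few compounds are considered here, and "the series" means these few. Any claim that something is new, unique, unknown or untested is made for them only; others in the source may bear on it.

Measured in a functional assay on HeLa cells (Homo sapiens) for inhibition, read by sulforhodamine B assay; a lower number here means a stronger inhibitor, a higher number a weaker inhibitor:
- Compound 1 `O=C1C(Nc2ccc(Br)cc2)=CC(=O)c2c1nc1n2[C@H]2OC[C@@H](O)[C@H]2OC1`: 5220 nM
- Compound 2 `O=C1C(N2CCCC2)=CC(=O)c2c1nc1n2[C@H]2OC[C@@H](O)[C@H]2OC1`: > 16000 nM, a limit of the assay, not a number
- Compound 3 `CCCc1ccc(NC2=CC(=O)c3c(nc4n3[C@H]3OC[C@@H](O)[C@H]3OC4)C2=O)cc1`: 6030 nM

Compound 3 stands level with compound 1: a 1.2-fold higher number from compound 1 to compound 3 (0.06 log units; within the scatter). The next structure, compound 4 `O=C1C(Nc2cccc(F)c2)=CC(=O)c2c1nc1n2[C@H]2OC[C@@H](O)[C@H]2OC1`, carries 3-fluorophenyl in place of 4-propylphenyl on an amine nitrogen.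

Going by the values given here, two measured steps bear on this. Exchanging the substituent on the aromatic ring gave a 1.2-fold higher number from compound 1 to compound 3 (0.06 log units; within the scatter), whereas replacing the whole (4-bromophenyl)amino group with pyrrolidin-1-yl gave an at least 3.0-fold higher number from compound 1 to compound 2 (0.48 log units; beyond the scatter). Compound 4 keeps an aromatic ring on the amine nitrogen, so its change resembles the first step, and no shift beyond the scatter is expected in this assay.

The expected step is a 1.0-fold lower number from compound 3 to compound 4 (0.00 log units; within the scatter).

For compound 4 the estimated value is 6000 nM, with an expected range of 2500 nM to 14000 nM.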

Compound 4, half-maximal inhibitory concentration: > 8000 nM
Compound 4: only a limit was reported (the forecaster's own chance of this, stated with the estimate: 15%); middle value at least 1.3-fold (0.12 log units) away from the limit.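

In this assay compound 4 gives only a limit of the assay, > 8000 nM. The 3-fluorophenyl change gives an at least 1.3-fold higher number from compound 3 to compound 4 (0.12 log units; that floor lies within the scatter), and an at least 1.5-fold higher number from compound 1 to compound 4 (0.18 log units; that floor lies within the scatter), so neither floor establishes a change at this amine nitrogen, although a fluorine-bearing aryl group now joins the 4-bromophenyl and 4-propylphenyl groups here. The step between the two limits of compound 2 and compound 4 cannot be read.

On these data alone, the true size of the step to compound 4 remains open. So does the reading for an aryl ring carrying a carboxylic acid or an amine.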